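The compounds below may be only part of what the source reports. "The series", "measured", "known", "first", "only" and "open" are said of these compounds alone.

Compound 1 `CC(C)[C@H](C(=O)NCc1ccccc1)c1ccc(Cl)cc1` — in a functional assay on CHO cells for agonist activity at Free fatty acid receptor 2 (Homo sapiens), read by cAMP accumulation (a lower number here means a smaller maximal response, a higher number a larger maximal response), compound 1 gives < 30%
Compound 2 `CC(C)C(C(=O)Nc1ncccn1)c1ccc(Cl)cc1` — in this assay compound 2 gives 50%

Compound 1 stands at a limit of this assay rather than at a number: its value is < 30%, and this is the limit of < 30% in this assay, at which 1 of the 2 values shown sits. Compound 2, the other measured compound, gives 50% in this assay, so only compound 2 supplies a numerical maximal response here.

Compound 3 `Cc1csc(NC(=O)[C@H](c2ccc(Cl)cc2)C(C)C)n1` has not been measured in this assay. It differs from compound 1 in one place, (4-methyl-1,3-thiazol-2-yl in place of benzyl on an amide-type nitrogen). Among the measured compounds shown here, no measured step between two compounds that differ in a single place is available to calibrate this change, so the expected size of the step rests on the two values shown.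

Compound 2 gives 50% in this assay, and compound 1 gives only its limit of < 30%. On that basis the step from compound 1 to compound 3 is expected to be upward and to go beyond the scatter, estimated at a number at least 15 percentage points higher from compound 1 to compound 3 (beyond the scatter). Compound 3 is therefore expected to reach 45% in this assay, within a range from 25% to 65%.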

Compound 3, largest response reached (reported as efficacy), in percent of the reference or control that the assay uses: 87%
Compound 3: the middle estimate sits 42 percentage points below what was measured; the measured number lies above the stated range.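

Among the compounds shown here, at the amide-type nitrogen, 4-methyl-1,3-thiazol-2-yl in place of benzyl gives the first single-place step that can be read in this assay: a number at least 57 percentage points higher from compound 1 to compound 3 (beyond the scatter). For the compounds shown here, this shows that the maximal response depends strongly on the group at this position, which the earlier compounds could not show, since they offered no single-place comparison. The step has only a lower bound because compound 1 stands at a limit and not at a number: the limit of < 30% in this assay, at which 1 of the 3 values shown sits.

The compounds shown leave open which part of the change carries the step, as the five-membered aromatic ring with 2 hetero atoms, its sulfur and nitrogen, and its methyl all enter together while the benzyl leaves. Plain thiazol-2-yl would speak to the role of the methyl and phenyl to that of the carbon linking the benzyl ring to the nitrogen, while a carboxylic acid on the ring would test how far the position tolerates a charged group.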